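The compounds below may be only part of what the source reports. "The series", "measured", "known", "first", "only" and "open" are said of these compounds alone.

Measured compounds:
- compound 1, `CN(CCC1CCNCC1)C(=O)c1ccc2c(c1)CC(CC(=O)O)C(=O)N(CCC(C)(C)C)C2`, giving 27 nM in a functional assay (plasma) for inhibition, with Homo sapiens as the target; a lower number here means a stronger inhibitor, a higher number a weaker inhibitor
- compound 2, `CN(CCC1CCNCC1)C(=O)c1ccc2c(c1)CC(CC(=O)O)C(=O)N(Cc1ccccc1)C2`, giving 36 nM in this assay
- compound 3, `CC(C)CCN1Cc2ccc(C(=O)N(C)CCC3CCNCC3)cc2CC(CC(=O)O)C1=O`, giving 32 nM in this assay

Compound 1 has the lowest of the three numbers in this assay, but its margin is thin: its nearest neighbour is compound 3 at a 1.2-fold higher number from compound 1 to compound 3 (0.07 log units; within the scatter), and even the furthest, compound 2, stands only at a 1.3-fold higher number from compound 1 to compound 2 (0.12 log units; within the scatter). Between compounds 2 and 3 the difference is a 1.1-fold lower number from compound 2 to compound 3 (0.05 log units; within the scatter). None of these three steps reaches beyond the scatter, so the three measured compounds cannot be ranked.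

Compound 4 is `CN(CCC1CCNCC1)C(=O)c1ccc2c(c1)CC(CC(=O)O)C(=O)N(C)C2`. It differs from compound 1 in one place: hydrogen in place of neopentyl on a saturated chain carbon bound to an amide-type nitrogen in a ring. Among the measured compounds shown here, the steps that bear on this are those in which the same saturated chain carbon carries a different group: phenyl in place of neopentyl from compound 1 to compound 2, and isobutyl in place of phenyl from compound 2 to compound 3. Each of those swaps left the number essentially unchanged. For the measured compounds named here, the change to compound 4, however, removes the group altogether rather than exchanging it for another of similar size, which no measured step covers. The expectation for compound 4 is therefore a step of a 2.2-fold higher number from compound 1 to compound 4 (0.35 log units; beyond the scatter), most likely a somewhat higher number, with wide uncertainty. Compound 4 is estimated to give 60 nM in this assay, in a range from 20 nM to 200 nM.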

Compound 4, half-maximal inhibitory concentration: 33 nM
Compound 4: middle estimate off by 1.8-fold (0.26 log units), on the high side, and the stated range covers the measured number.
By their numbers in this assay, from the lowest: compounds 1, 3, 4 and 2 (each within the scatter of the next).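

Replacing neopentyl with hydrogen on a saturated chain carbon bound to an amide-type nitrogen in a ring, which the same difference cut one bond further out reads as 3,3-dimethylbutyl to methyl, gives in this assay a step of a 1.2-fold higher number from compound 1 to compound 4 (0.09 log units; within the scatter) that cannot be told from repeat measurement. The comparisons with the other two groups read the same way, with a 1.0-fold higher number from compound 3 to compound 4 (0.01 log units; within the scatter) for isobutyl and a 1.1-fold lower number from compound 2 to compound 4 (0.04 log units; within the scatter) for phenyl, so the earlier exchanges of one sizeable group for another now extend to the removal of that group, and across these four compounds the number does not depend on what sits at this place. No independent measurement is available to explain why this position tolerates the change.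

The compounds shown leave open whether an amine or a carboxylic acid carried on this chain, or a chain longer than 3,3-dimethylbutyl, would be tolerated in the same way. They also leave open whether this insensitivity would persist if the carboxylic acid of the shared core were replaced by an ester or an amide.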